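A few compounds are considered here, and "the series" means these few. Any claim that something is new, unique, unknown or untested is made for them only; others in the source may bear on it.

Measured compounds:
compound 1, `COc1ccc(F)cc1Nc1cc(NC(=O)Nc2c(Cl)cccc2Cl)ncn1`, 78%
compound 2, `COc1cc(NC(=O)Nc2cc(Nc3cccc(C(C)(C)C)c3)ncn2)cc(OC)c1`, 48.7%
compound 3, `COc1ccc(Nc2cc(NC(=O)Nc3c(Cl)cccc3Cl)ncn2)cc1C`, 63.1%

All three were tested in a functional assay on HCC827 cells (Homo sapiens) for inhibition, read by MTT assay, with a stated time of 48 h, tested at 10 uM; a lower number here means less inhibition, a higher number more inhibition at the concentration tested (going by the name of the read-out). Among them compound 3 stands second highest: compound 1 is above it and compound 2 below it, each gap beyond the usual scatter. Among the measured compounds shown here, the one step between measured compounds that differ in a single place is a number 14.9 percentage points lower from compound 1 to compound 3 (beyond the scatter), a modest drop.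

Compound 4, `COc1cc(NC(=O)Nc2cc(Nc3ccc(OC)c(C)c3)ncn2)cc(OC)c1`, is not yet measured. It differs from compound 3 as follows: 3,5-dimethoxyphenyl in place of 2,6-dichlorophenyl on an amide-type nitrogen. For the measured compounds named here, no measured step addresses this exchange; the known step from compound 1 to compound 3 concerns a different group on a different nitrogen. The only other hint is that compound 2 also carries the 3,5-dimethoxyphenyl on its amide-type nitrogen, and in this assay compound 2 gives 48.7%, the lowest of the three numbers, although it differs from compound 3 in two places, so no single step can be read from it. On that thin basis a downward step is expected, roughly a number 13.1 percentage points lower from compound 3 to compound 4 (beyond the scatter). Compound 4 is therefore estimated to give 50% in this assay, plausibly between 30% and 70%.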

Compound 4, a percentage reported as inhibition, at one concentration (the size of the read-out at that concentration, not a potency): 48.3%
Estimate against measurement, compound 4: 1.7 percentage points above; measured number inside the range.
By their numbers in this assay, from the lowest: compounds 4 and 2 (each within the scatter of the next); then compound 3; then compound 1.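

In this assay, among the compounds shown here, the exchange of 2,6-dichlorophenyl for 3,5-dimethoxyphenyl on the amide-type nitrogen can now be read directly for the first time, and it comes with a number 14.8 percentage points lower from compound 3 to compound 4 (beyond the scatter). The group on the other nitrogen gives a different picture when 3,5-dimethoxyphenyl is present: putting 4-methoxy-3-methylphenyl in place of 3-(tert-butyl)phenyl gives a number 0.4 percentage points lower from compound 2 to compound 4 (within the scatter), so this pair of compounds cannot be told apart in this assay. Nothing at hand explains either step.

The compounds shown leave open whether the step belongs to the chlorines, the methoxy groups or both, since a plain phenyl ring or a ring with a single chlorine or a single methoxy group on this nitrogen is not among them, and a ring carrying an amine or a carboxylic acid would test a very different kind of group. From the compounds shown here alone, it also remains open whether 5-fluoro-2-methoxyphenyl, the group on the aromatic-ring nitrogen of compound 1, would give a higher number alongside 3,5-dimethoxyphenyl on the amide-type nitrogen.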